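Adding a second chloro to compound 2: an estimate

A few compounds are considered here, and "the series" means these few. Any claim that something is new, unique, unknown or untested is made for them only; others in the source may bear on it.

Measured compounds:
- Compound 1 `C=C(C)c1cccc(N2CCN(C(=O)c3oc(C)nc3-c3ccccc3F)CC2)c1` gives "not active" (no number reported) in a functional assay on HL-60 cells (Homo sapiens) for inhibition, read by MTT assay, with a stated time of 72 h; a lower number here means a stronger inhibitor, a higher number a weaker inhibitor
- Compound 2 `Cc1nc(-c2ccccc2F)c(C(=O)N2CCN(c3cccc(Cl)c3)CC2)o1` gives 39.4 nM in this assay
- Compound 3 `Cc1nc(-c2ccc(F)cc2)c(C(=O)N2CCN(c3cccc(Cl)c3)CC2)o1` gives 40.1 nM in this assay

Compound 2 has the lowest of the two numbers shown, but compound 3 sits so close that the two cannot be told apart: the step of a 1.0-fold higher number from compound 2 to compound 3 (0.01 log units; within the scatter) lies within the scatter. Compound 1, which carries a different group in place of the chloro on the phenyl, reports no number at all.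

Compound 4 `Cc1nc(-c2ccccc2F)c(C(=O)N2CCN(c3cc(Cl)cc(Cl)c3)CC2)o1` is compound 2 with a second chloro added: chloro in place of hydrogen on an aromatic carbon, on an aromatic carbon of a six-membered aromatic ring of carbon only, meta to a chloro group. Among the measured compounds shown here, no measured step covers this change; the one step known, from compound 2 to compound 3, concerns the fluorophenyl and is flat, so it offers little guidance. For the measured compounds named here, the only hint is that compound 1, without a chloro on that phenyl, is not active, so the chloro seems to matter, and a second one is expected to leave potency roughly unchanged or slightly improved.

Compound 4 is therefore estimated at 30 nM, with a range of 10 nM to 120 nM, an expected step of a 1.3-fold lower number from compound 2 to compound 4 (0.12 log units; within the scatter).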

Compound 4, half-maximal inhibitory concentration: 60.2 nM
Compound 4: middle estimate off by 2.0-fold (0.30 log units), on the low side, and the stated range covers the measured number.
By their numbers in this assay, from the lowest: compounds 2, 3 and 4 (each within the scatter of the next).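

Adding a chloro to the ring, turning 3-chlorophenyl into 3,5-dichlorophenyl, gives a 1.5-fold higher number from compound 2 to compound 4 (0.18 log units; within the scatter) in this assay, so compound 2 and compound 4 cannot be told apart. Among the compounds shown here, this is the first sign that this ring position, meta to a chloro group, can carry a chloro and still give a measured number close to those of the other chloro compounds, whereas the earlier step concerned only the fluorophenyl. Nothing available explains this result.

As far as these compounds go, whether other groups would give a similar number at this place, such as a methoxy group or an amine, remains open. From the compounds shown here alone, it is also open whether the 3,5-dichlorophenyl would behave the same way alongside the 4-fluorophenyl of compound 3.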